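A few compounds are considered here, and "the series" means these few. Any claim that something is new, unique, unknown or untested is made for them only; others in the source may bear on it.

Compound 3 `CSC[C@H](NC(=O)c1ccc(C#Cc2ccccc2)cc1)C(=O)NO` gives 3 in a physicochemical assay for lipophilicity; on this read-out higher numbers stand for higher lipophilicity and lower numbers for lower lipophilicity; compound 1 `C#CCNC(=O)C[C@H](NC(=O)c1ccc(C#Cc2ccccc2)cc1)C(=O)NO` gives 3; compound 2 `O=C(N[C@@H](CO)C(=O)NO)c1ccc(C#Cc2ccccc2)cc1` gives 2.

On these numbers compound 3 stands level with compound 1, the two together the highest of the three; compound 2 lies furthest away, a number 1.00 log units higher from compound 2 to compound 3 (beyond the scatter). Compound 4 `O=C(C[C@H](NC(=O)c1ccc(C#Cc2ccccc2)cc1)C(=O)NO)NCCCO` differs from compound 3 in one place: (3-hydroxypropyl)carbamoyl in place of methylsulfanyl on a saturated chain carbon, two bonds along the chain from an amide-type nitrogen and a carbonyl carbon. Among the compounds with values here, two measured steps bear on this. no change at the digits printed from compound 1 to compound 3 (within the scatter) shows that exchanging propargylcarbamoyl for methylsulfanyl left this assay unchanged; a number 1.00 log units higher from compound 2 to compound 3 (beyond the scatter) shows that hydroxy in place of methylsulfanyl sits a modest amount lower. The entering group combines a carbamoyl with a hydroxy, so a drop smaller than the full hydroxy step is expected, a number 0.70 log units lower from compound 3 to compound 4 (beyond the scatter). Compound 4 is therefore estimated at 2.3, with a range from 1.7 to 2.9.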

Compound 4, distribution coefficient: 2
The estimate for compound 4 lay 0.30 log units above the measured number, within the range that was stated.
By their numbers in this assay, from the lowest: compounds 2 and 4 (each within the scatter of the next); then compounds 1 and 3 (each within the scatter of the next).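

At this position in this assay, the carbamoyl linkage alone does not set the number: with the chain end changed from the propargyl form to the hydroxypropyl form, the read-out gives a number 1.00 log units lower from compound 1 to compound 4 (beyond the scatter). The larger side chain also separates from methylsulfanyl, with a number 1.00 log units lower from compound 3 to compound 4 (beyond the scatter), yet it matches the plain hydroxy group, with no change at the digits printed from compound 2 to compound 4 (within the scatter). Nothing at hand explains these steps.

From the compounds shown here alone, whether an amine or a carboxylic acid at the chain end would fall at the same level remains open. So does the effect of a longer chain carrying the terminal hydroxy.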